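A few compounds are considered here, and "the series" means these few. Any claim that something is new, unique, unknown or untested is made for them only; others in the source may bear on it.

Measured compounds:
- compound 1, `Cc1c(C(=O)Nc2ccc(Oc3ccnc4[nH]ccc34)cc2)nnn1-c1ccccc1F`, gives 280 nM in a functional assay on MCF7 cells (Homo sapiens) for cytotoxicity, read by MTT assay, with a stated time of 72 h; on this read-out higher numbers stand for weaker inhibition and lower numbers for stronger inhibition.
- compound 2, `Cc1c(C(=O)Nc2ccc(Oc3ccnc4[nH]ccc34)cc2)nnn1-c1ccc(F)cc1`, gives 390 nM.
- compound 3, `O=C(Nc1ccc(Oc2ccnc3[nH]ccc23)cc1)c1nnn(-c2ccccc2F)c1C(F)(F)F`, gives 290 nM.

Compound 3 stands second highest of the three numbers: its nearest neighbour is compound 1, a 1.0-fold higher number from compound 1 to compound 3 (0.02 log units; within the scatter), and its furthest is compound 2, which lies within the scatter as well. Compound 4, `O=C(Nc1ccc(Oc2ccnc3[nH]ccc23)cc1)c1nnn(-c2ccc(F)cc2)c1C(F)(F)F`, has not yet been measured. It differs from compound 3 by 4-fluorophenyl in place of 2-fluorophenyl on an aromatic nitrogen. The same change was already made on the methyl-bearing core, from compound 1 to compound 2: a 1.4-fold higher number from compound 1 to compound 2 (0.14 log units; within the scatter). That single step is the only one bearing on the present change, and it stays within the scatter, so no shift beyond the scatter is expected for compound 4; the methyl-to-trifluoromethyl step, a 1.0-fold higher number from compound 1 to compound 3 (0.02 log units; within the scatter), gives no reason to expect the fluorophenyl change to behave differently on the trifluoromethyl core. Compound 4 is therefore expected at 400 nM, with a range of 200 nM to 800 nM, which means an expected step of a 1.4-fold higher number from compound 3 to compound 4 (0.14 log units; within the scatter), because the comparable step was a 1.4-fold higher number from compound 1 to compound 2 (0.14 log units; within the scatter).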

Compound 4, half-maximal inhibitory concentration: 210 nM
Compound 4: middle estimate off by 1.9-fold (0.28 log units), on the high side, within the range that was stated.
By their numbers in this assay, from the lowest: compounds 4, 1, 3 and 2 (each within the scatter of the next).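

In this assay the change to 4-fluorophenyl from 2-fluorophenyl on the aromatic nitrogen, now read on the trifluoromethyl core, gives a 1.4-fold lower number from compound 3 to compound 4 (0.14 log units; within the scatter) and so no longer rests on the methyl core alone. The two readings of this change do not share a direction, yet neither step nor the gap between them leaves the scatter: the same change on two cores in this assay, a 1.4-fold higher number (0.14 log units; within the scatter) from compound 1 to compound 2 and a 1.4-fold lower number (0.14 log units; within the scatter) from compound 3 to compound 4, 1.9-fold (0.28 log units) apart, within the scatter of two such steps. Trifluoromethyl in place of methyl, now read with 4-fluorophenyl, gives a 1.9-fold lower number from compound 2 to compound 4 (0.27 log units; within the scatter) and also stays within the scatter on both cores: the same change on two cores in this assay, a 1.0-fold higher number (0.02 log units; within the scatter) from compound 1 to compound 3 and a 1.9-fold lower number (0.27 log units; within the scatter) from compound 2 to compound 4, 1.9-fold (0.28 log units) apart, within the scatter of two such steps.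

Going by these compounds, what an unsubstituted phenyl or a 3-fluorophenyl on the aromatic nitrogen would give remains open. So does the effect of an amine or a nitrile in place of methyl or trifluoromethyl on the aromatic carbon.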